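From chloro to methoxy on a shared core

A few compounds are considered here, and "the series" means these few. Any claim that something is new, unique, unknown or untested is made for them only; others in the source may bear on it.

Measured so far in a functional assay on KYSE-410 cells (Homo sapiens) for antiproliferative activity, read by MTT assay, with a stated time of 72 h; a higher number here means a weaker inhibitor, a lower number a stronger inhibitor:
- compound 1 `O=C(Nc1ccc(F)cc1)c1ccnc2cc(Br)ccc12` gives > 20000 nM, which is a limit
- compound 2 `O=C(Nc1cc(F)cc(F)c1)c1cc(=O)[nH]c2cc(Br)ccc12` gives 11200 nM
- compound 3 `O=C(Nc1cc(F)cc(F)c1)c1cc(=O)[nH]c2cc(Cl)ccc12` gives 11000 nM

Compound 3, at 11000 nM, matches compound 2 within the scatter. Compound 4 `COc1ccc2c(C(=O)Nc3cc(F)cc(F)c3)cc(=O)[nH]c2c1` carries methoxy in place of chloro on an aromatic carbon. Among the measured compounds shown here, one measured step bears on this change, a 1.0-fold lower number from compound 2 to compound 3 (0.01 log units; within the scatter), and it swaps a different pair of groups. With so little to go on, no shift beyond the scatter is expected in this assay. The expected change is a 1.1-fold higher number from compound 3 to compound 4 (0.04 log units; within the scatter) in size. For compound 4 the estimate is 12000 nM, with an expected range of 5500 nM to 20000 nM here.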

Compound 4, half-maximal inhibitory concentration: > 20000 nM
Compound 4 ended at the assay's limit (the forecaster's own chance of this, stated with the estimate: 15%); middle value at least 1.6-fold (0.22 log units) away from the limit.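

In this assay, methoxy in place of chloro gives an at least 1.8-fold higher number from compound 3 to compound 4 (0.25 log units; that floor lies within the scatter), and methoxy in place of bromo gives an at least 1.7-fold higher number from compound 2 to compound 4 (0.25 log units; that floor lies within the scatter). Chloro and bromo could not be told apart at this position, whereas methoxy is the first change here that may shift the number, although both floors lie within the scatter. Compound 4 gives a limit rather than a number: the limit of > 20000 nM in this assay, at which 2 of the 4 values shown sit.

Going by these compounds, how far compound 4 really lies from compound 2 and compound 3 stays open. So does how an amine or a carboxylic acid would fare at this position.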